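The compounds below may be only part of what the source reports. "The series", "measured", "known", "first", "only" and "open" are said of these compounds alone.

Measured so far in a physicochemical assay for solubility; on this read-out lower numbers stand for lower solubility and higher numbers for higher solubility:
Compound 1 `CC(C)(C)OC(=O)N1CCC[C@@H]1C(=O)N1CCC(NS(=O)(=O)c2cc(S(=O)(=O)c3ccccc3)ccc2C(F)(F)F)CC1` gives 25000 nM.
Compound 2 `CC(C)(C)OC(=O)N1C(=O)CC[C@H]1C(=O)N1CCC(NS(=O)(=O)c2cc(S(=O)(=O)c3ccccc3)ccc2C(F)(F)F)CC1` gives 50000 nM.

Only these two compounds carry numbers in this assay, and their two values lie within the usual scatter of each other, so compound 1 cannot be separated from compound 2 on this read-out. Going by the values given here, no pair of measured compounds differs in a single place, so nothing yet shows how the shared core answers to a change at one position. The unmeasured compound 3 `CN(C)CC(=O)N1CCC[C@H]1C(=O)N1CCC(NS(=O)(=O)c2cc(S(=O)(=O)c3ccccc3)ccc2C(F)(F)F)CC1` differs from compound 1 in one place: 1-(((dimethylamino)methyl)carbonyl)pyrrolidin-2-yl in place of 1-(tert-butoxycarbonyl)pyrrolidin-2-yl on a carbonyl carbon. The two measured compounds say nothing about a change of this kind, so the expectation rests on the change itself and carries wide uncertainty. For compound 3 the expected step in this assay is upward and beyond the scatter, a 4.0-fold higher number from compound 1 to compound 3 (0.60 log units; beyond the scatter). Compound 3 is estimated to give 100000 nM, with a likely range from 30000 nM to 300000 nM.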

Compound 3, solubility: 100000 nM
The estimate for compound 3 equals the measured number at the digits printed; low and high end bracket the measured number.
By their numbers in this assay, from the lowest: compounds 1, 2 and 3 (each within the scatter of the next, the first and the last beyond it).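

In this assay, going by these compounds alone, putting 1-(((dimethylamino)methyl)carbonyl)pyrrolidin-2-yl in place of 1-(tert-butoxycarbonyl)pyrrolidin-2-yl on a carbonyl carbon gives a 4.0-fold higher number from compound 1 to compound 3 (0.60 log units; beyond the scatter), the first change at a single place. It shows that this position can move the read-out beyond the scatter, even though the two groups have the same printed counts of hydrogen-bond donors and acceptors and differ in their atoms by only a few. No measurement shown accounts for the step.

The compounds shown leave open whether the step follows the dimethylamino group itself or the departure of the tert-butoxy part. An acetyl group, a carboxylic acid or a longer chain carrying the same amine at this place would help separate those two readings.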